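This account rests on a few compounds, and the source may have more. Where it says the series, first, only, none or still open, it means among the compounds named here.

For the measured compounds named here, the three compounds measured so far share one core, carried by compound 1 `CCCCNC(=O)Nc1cc2nc(C3CCCCC3)[nH]c2cc1N(CC)CC`, compound 2 `CCOCCOC(=O)Nc1cc2nc(C3CCCCC3)[nH]c2cc1N(C)C` and compound 3 `CCCNC(=O)Nc1cc2nc(C3CCCCC3)[nH]c2cc1N1CCCC1`. In an ADME assay on Vero cells (Chlorocebus sabaeus) for cytotoxicity, read by resazurin assay, with a stated time of 3 days (a lower number here means a stronger inhibitor, a higher number a weaker inhibitor), compound 1 gives > 100 ug/mL, which is a limit of the assay rather than a number. Compound 2 likewise reaches only the limit of > 100 ug/mL in this assay. Compound 3 too stops at the limit of > 100 ug/mL in this assay. Compound 2 therefore stands nowhere in particular among the numbers shown: the only evidence is the limit of > 100 ug/mL in this assay, at which 3 of the 3 values shown sit, and no ordering of the three can be read from it. Going by the values given here, no step between two measured compounds that differ in one place is available. The compound still to be measured is compound 4 `CCCCOC(=O)Nc1cc2nc(C3CCCCC3)[nH]c2cc1N(C)C`, which differs from compound 2 by ethyl in place of ethoxy on a saturated chain carbon, two bonds along the chain from an oxygen next to a carbonyl group. With every measured value resting on the same limit, the step in this assay from compound 2 to compound 4 is expected to be none beyond the scatter, both values sitting at the limit. The estimate for compound 4 is accordingly 120 ug/mL, within 50 ug/mL to 300 ug/mL. The step this estimate implies is expected to be a step that the limit leaves unreadable from compound 2 to compound 4.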

Compound 4, half-maximal inhibitory concentration: > 100 ug/mL
Compound 4: only a limit was reported; the forecaster's own chance of this, stated with the estimate: 75%; the middle value is on the limit's open side.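

In this assay, compound 4 gives > 100 ug/mL, which is a limit of the assay and not a number. No step from compound 2 to compound 4 can be read, as every value shown rests on the same limit: the limit of > 100 ug/mL in this assay, at which 4 of the 4 values shown sit. The compounds shown leave open at what concentration any of them would reach half-maximal inhibition in this assay.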